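The compounds below may be only part of what the source reports. "The series", "measured", "known", "first", "only" and "open" are said of these compounds alone.

Measured in a functional assay on microsomes from liver (Rattus norvegicus, strain Wistar) for inhibition, read by spectrophotometry, with a stated time of 60 min; a lower number here means a stronger inhibitor, a higher number a weaker inhibitor:
- Compound 1 `COc1ccc(C(=O)ON=C2CC(c3ccc(O)c(OC)c3)N(C)C(c3ccc(O)c(OC)c3)C2)c(OC)c1`: 52000 nM
- Compound 2 `COc1cc(C2CC(=NOC(=O)c3cccc(O)c3)CC(c3ccc(O)c(OC)c3)N2C)ccc1O`: 25300 nM
- Compound 3 `COc1cc(C2CC(=NOC(=O)c3ccccc3O)CC(c3ccc(O)c(OC)c3)N2C)ccc1O`: 24100 nM

Compound 3 and compound 2 stand level, with a 1.0-fold lower number from compound 2 to compound 3 (0.02 log units; within the scatter). Both lie modestly clear of compound 1, with a 2.1-fold lower number from compound 1 to compound 2 (0.31 log units; beyond the scatter) and a 2.2-fold lower number from compound 1 to compound 3 (0.33 log units; beyond the scatter).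

Compound 4 `COc1cc(C2CC(=NOC(=O)c3ccc([N+](=O)[O-])cc3)CC(c3ccc(O)c(OC)c3)N2C)ccc1O` carries 4-nitrophenyl in place of 2-hydroxyphenyl on a carbonyl carbon. All three measured steps changed the group at this same place, and none went beyond modest. Among the compounds with values here, no measured compound carries 4-nitrophenyl, so the direction stays open, and little change is expected in this assay. The estimate amounts to a 1.2-fold higher number from compound 3 to compound 4 (0.10 log units; within the scatter), an expected shift no larger than the scatter. For compound 4 the expected value is 30000 nM, with an estimated range of 12000 nM to 70000 nM.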

Compound 4, half-maximal inhibitory concentration: 82000 nM
For compound 4 the middle estimate is 2.7-fold (0.44 log units) below the measured one, outside the stated range (above it).
By their numbers in this assay, from the lowest: compounds 3 and 2 (each within the scatter of the next); then compounds 1 and 4 (each within the scatter of the next).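

In this assay, within the data shown here, 4-nitrophenyl on this carbonyl carbon gives a 3.4-fold higher number from compound 3 to compound 4 (0.53 log units; beyond the scatter) and a 3.2-fold higher number from compound 2 to compound 4 (0.51 log units; beyond the scatter), both modest, so the group at this place can also raise the number, whereas the earlier steps here only lowered it or left it level. Against 2,4-dimethoxyphenyl, it gives a 1.6-fold higher number from compound 1 to compound 4 (0.20 log units; within the scatter), so among these four compounds the two carrying a hydroxyphenyl hold the lower numbers. Nothing available here accounts for this difference. The compounds shown leave open how a plain phenyl, an aminophenyl or a carboxyphenyl would read at this place. They also cannot show whether the hydroxyl lowers the number or the nitro and dimethoxy groups raise it.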